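This account rests on a few compounds, and the source may have more. Where it says the series, first, only, none or still open, it means among the compounds named here.

In a functional assay, with a stated time of 10 min (on this read-out higher numbers stand for weaker inhibition and lower numbers for stronger inhibition), compound 3 `CCOc1cc(OC)ccc1C(C)=O` gives 35300000 nM and stands within the scatter of both other measured compounds, compound 1 `CCOc1cc(OC)c(Br)cc1C(C)=O` with 57700000 nM on the same scale and compound 2 `CCCCOc1cc(OC)c(Br)cc1C(C)=O` with 56900000 nM on that scale too. The change to compound 4 `CCCCOc1cc(OC)ccc1C(C)=O` is ethoxy to butoxy, with ethyl in place of hydrogen on a saturated chain carbon, two bonds along the chain from an oxygen on an aromatic ring. The same change has been measured once, in the bromo compounds: a 1.0-fold lower number from compound 1 to compound 2 (0.01 log units; within the scatter) is the direct precedent. Going by the values given here, the other measured step, hydrogen in place of bromo on an aromatic carbon, gives a 1.6-fold lower number from compound 1 to compound 3 (0.21 log units; within the scatter) and so offers no sign that the precedent should differ without bromo. This rests on a single pair. The expected step is a 1.0-fold lower number from compound 3 to compound 4 (0.00 log units; within the scatter) in this assay with nothing beyond the scatter anticipated. Compound 4 is estimated at 35000000 nM with 20000000 nM to 60000000 nM as the expected range.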

Compound 4, half-maximal inhibitory concentration: 57200000 nM
Compound 4: middle estimate off by 1.6-fold (0.21 log units), on the low side; low and high end bracket the measured number.
By their numbers in this assay, from the lowest: compounds 3, 2, 4 and 1 (each within the scatter of the next).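

In this assay, ethoxy to butoxy now reads on the core without bromo as well as on the bromo core, with a 1.6-fold higher number from compound 3 to compound 4 (0.21 log units; within the scatter), and the two readings agree: the same change on two cores in this assay, a 1.0-fold lower number (0.01 log units; within the scatter) from compound 1 to compound 2 and a 1.6-fold higher number (0.21 log units; within the scatter) from compound 3 to compound 4, 1.6-fold (0.22 log units) apart, within the scatter of two such steps. Hydrogen in place of bromo now also reads on the butoxy core, with a 1.0-fold higher number from compound 2 to compound 4 (0.00 log units; within the scatter), and again the two readings agree: the same change on two cores in this assay, a 1.6-fold lower number (0.21 log units; within the scatter) from compound 1 to compound 3 and a 1.0-fold higher number (0.00 log units; within the scatter) from compound 2 to compound 4, 1.6-fold (0.22 log units) apart, within the scatter of two such steps. Across these four compounds, neither change shows an effect beyond the scatter on either core, and neither change alters the reading of the other.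

Open, from the compounds shown here alone, is whether a chain longer than butoxy, or an amine or a carboxylic acid carried on that chain, would move the number beyond the scatter. Equally open, going by these compounds, is whether a nitrile or a carboxylic acid in place of bromo would do so.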